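The source may hold more compounds than are shown below. What is called first, only, known or untested is meant among the compounds shown, and "the series" means these compounds.

In a functional assay on DU-145 cells (Homo sapiens) for inhibition, read by MTT assay, with a stated time of 72 h (on this read-out higher numbers stand for weaker inhibition and lower numbers for stronger inhibition), compound 1 (`COc1ccc(N2CCN(C3=CC(=O)c4ccccc4C3=O)CC2)cc1`) gives 46100 nM, compound 2 (`O=C1C=C(N2CCN(c3ccccc3)CC2)C(=O)c2ccccc21`) gives 9900 nM and compound 3 (`Cc1ccccc1N1CCN(C2=CC(=O)c3ccccc3C2=O)CC1`) gives 5700 nM. Compound 3 therefore sits level with compound 2, the step being a 1.7-fold lower number from compound 2 to compound 3 (0.24 log units; within the scatter), and clearly apart from compound 1, with an 8.1-fold lower number from compound 1 to compound 3 (0.91 log units; beyond the scatter) and, alongside it, a 4.7-fold lower number from compound 1 to compound 2 (0.67 log units; beyond the scatter). Compound 4 (`Cc1ccccc1N1CCN(C2=CC(=O)c3cccc(O)c3C2=O)CC1`) differs from compound 3 by hydroxy in place of hydrogen on an aromatic carbon. All three measured steps change only the group on the amine nitrogen in a ring, so none tests this change directly. They give no direction, and no step beyond the scatter is expected in this assay. The expected step is a 1.6-fold lower number from compound 3 to compound 4 (0.21 log units; within the scatter). Compound 4 is estimated at 3500 nM, within an expected range of 700 nM to 15000 nM.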

Compound 4, half-maximal inhibitory concentration: 2300 nM
The estimate for compound 4 lay 1.5-fold (0.18 log units) above the measured number; low and high end bracket the measured number.
By their numbers in this assay, from the lowest: compound 4; then compounds 3 and 2 (each within the scatter of the next); then compound 1.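

In this assay, hydroxy in place of hydrogen gives a 2.5-fold lower number from compound 3 to compound 4 (0.39 log units; beyond the scatter), the only change shown on the fused two-ring system rather than on the group carried by the amine nitrogen. This aromatic carbon, ortho to a fused ring, therefore accepts a substituent, and here the hydroxy goes with stronger inhibition. Nothing measured here bears on why the number falls. Going by these compounds, whether methoxy, an amine or fluorine on this carbon would act the same remains open. Also open, on these data alone, is whether hydroxy would give a similar step with the phenyl of compound 2 or the 4-methoxyphenyl of compound 1.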